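The source may report more compounds than this note shows. Statements on the series, on what has been measured and on what is new or still open speak of the compounds shown alone.

The measurements at hand, all from a functional assay on A549 cells (Homo sapiens) for cytotoxicity, read by MTT assay, with a stated time of 48 h; a higher number here means a weaker inhibitor, a lower number a stronger inhibitor:

Compound 1 `O=c1ccc2cc(OCc3cc(-c4ccccc4Cl)no3)ccc2o1` — "not determined" (no result reported).
Compound 2 `COc1cccc(-c2cc(COc3ccc4oc(=O)ccc4c3)on2)c1` — "not determined" (no result reported).
Compound 3 `O=c1ccc2cc(OCc3cc(-c4cccc([N+](=O)[O-])c4)no3)ccc2o1` — 36200 nM.

Compound 1 therefore stands without a single number; the same holds for compound 2, so only compound 3 offers a value, and that value sits far up the scale, marking a weak inhibitor in this assay. For the measured compounds named here, no step between measured compounds that differ in one place is available, so nothing measured tells how a small change on the outer phenyl ring shifts the read-out.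

Compound 4 `N#Cc1ccccc1-c1cc(COc2ccc3oc(=O)ccc3c2)on1` differs from compound 1 in one place: cyano in place of chloro on an aromatic carbon. Going by the values given here, since compound 1 has no number to step from, any expectation for compound 4 rests on the only value shown, that of compound 3, which is also a close relative carrying a different substituent on the same outer ring. On that basis a weak result is expected in this assay, with no clear reason to expect a shift beyond the scatter in either direction relative to compound 3. Compound 4 is therefore estimated at 30000 nM, with a plausible range from 8000 nM to 120000 nM.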

Compound 4, half-maximal inhibitory concentration: 55800 nM
Compound 4: the middle estimate sits 1.9-fold (0.27 log units) below what was measured, within the range that was stated.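

In this assay the swap of 3-nitrophenyl for 2-cyanophenyl shows a 1.5-fold higher number from compound 3 to compound 4 (0.19 log units; within the scatter) and so leaves these two compounds indistinguishable, although both the group and its place on the outer ring differ. For the compounds shown here, this is the only step that can be read, so the set now shows that two different outer rings can give values within the scatter of each other, though it shows nothing about other groups. Compound 1 has no number, so the change from chloro to cyano cannot be read, and nothing measured here explains the result.

Still open, on these data alone, is whether chloro and cyano at this position give different values. As far as these compounds go, it is also open whether a different group on that aromatic carbon, such as an amine or a carboxylic acid, would move the value beyond the scatter.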